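The source may hold more compounds than are shown below. What is called first, only, known or untested is meant among the compounds shown, and "the series" means these compounds.

Two measured compounds share one core. Compound 1 `COc1cc2c(cc1OC)C(CC(=O)Nc1cccc(Cl)c1)CC2` gives 37.5% in a functional assay on the whole organism (strain Wistar) for inhibition, with Rattus norvegicus as the target, read by paw edema, at a dose of 100 mg/kg by the oral route; a higher number here means more inhibition at the dose given (going by the name of the read-out), a lower number less inhibition. Compound 2 `COc1cc2c(cc1OC)C(CC(=O)Nc1cccc(C)c1)CC2` gives 16.5% in this assay. Among the compounds with values here, the one step between them, a number 21 percentage points lower from compound 1 to compound 2 (beyond the scatter), is a change of a substituent on the aromatic ring. On these two numbers compound 2 stands lowest, with compound 1 above it by a gap beyond the scatter.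

Compound 3 `COc1cc2c(cc1OC)C(CC(=O)Nc1ccncc1)CC2` has not yet been measured in this assay. Its difference from compound 2 is pyridin-4-yl in place of 3-methylphenyl on an amide-type nitrogen. Within the data shown here, this change, which swaps the whole aryl ring on the amide-type nitrogen, is not of the same kind as the step from compound 1 to compound 2, which altered only a ring substituent, so no measured step bears directly on it. Among the measured compounds shown here, the size and direction of the step are therefore open; the sole comparison available shows that a change on this ring can move the number by a modest amount beyond the scatter.

For compound 3 the expected step is a number 8.5 percentage points higher from compound 2 to compound 3 (within the scatter), an estimate near the measured pair. Compound 3 is estimated at 25%, with a range from 5% to 50%.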

Compound 3, a percentage reported as inhibition, in the whole organism at one dose (the size of the read-out at that dose, not a potency): 17%
Compound 3: the middle estimate sits 8 percentage points above what was measured; low and high end bracket the measured number.
By their numbers in this assay, from the lowest: compounds 2 and 3 (each within the scatter of the next); then compound 1.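

In this assay the aryl ring on the amide-type nitrogen is now exchanged as a whole, and pyridin-4-yl in place of 3-methylphenyl gives a number 0.5 percentage points higher from compound 2 to compound 3 (within the scatter), so this swap of a carbon-only ring for one holding a ring nitrogen leaves no difference that can be read at this dose. Pyridin-4-yl in place of 3-chlorophenyl gives a number 20.5 percentage points lower from compound 1 to compound 3 (beyond the scatter), which, together with a number 21 percentage points lower from compound 1 to compound 2 (beyond the scatter), sets compound 1 apart from both other compounds, while the ring of compound 2 and the ring of compound 3 cannot be told apart among these three. No measurement at hand accounts for the higher number of compound 1 or for the closeness of the other two.

The compounds shown leave open whether the number of compound 1 belongs to chloro specifically, since a bromo, fluoro or methoxy substituent and an unsubstituted phenyl do not appear among them. They also leave open how pyridin-3-yl or pyridin-2-yl on the same nitrogen would read, and whether a ring carrying an amine or a carboxylic acid would stand with compound 1 or with the other two.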